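A few compounds are considered here, and "the series" means these few. Any claim that something is new, unique, unknown or untested is made for them only; others in the source may bear on it.

Three compounds of this series have numbers in an assay on isolated protein for inhibition of Neprilysin (Oryctolagus cuniculus) (a higher number here means a weaker inhibitor, a lower number a stronger inhibitor), so far. Compound 1 `O=C(NCC(=O)N1[C@@H](c2ccccc2O)CC[C@H]1C(=O)O)[C@@H](S)Cc1ccccc1` gives 1 nM in this assay. Compound 2 `O=C(NCC(=O)N1[C@@H](c2cccc(O)c2)CC[C@H]1C(=O)O)[C@@H](S)Cc1ccccc1` gives 2.4 nM, and compound 3 `O=C(NCC(=O)N1[C@@H](c2ccccc2O)CC[C@H]1C(=O)O)[C@@H](S)Cc1ccc(O)cc1` gives 3.5 nM. Compound 3 thus carries the highest of the three numbers; its gap to compound 2 lies within the scatter, while its gap to compound 1 is beyond it. For the measured compounds named here, the two steps so far are both modest: a 2.4-fold higher number from compound 1 to compound 2 (0.38 log units; beyond the scatter), and a 3.5-fold higher number from compound 1 to compound 3 (0.54 log units; beyond the scatter).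

Compound 4 `Nc1ccc([C@H]2CC[C@@H](C(=O)O)N2C(=O)CNC(=O)[C@@H](S)Cc2ccc(O)cc2)cc1` differs from compound 3 in one place: 4-aminophenyl in place of 2-hydroxyphenyl on a saturated ring carbon. Going by the values given here, the step that bears most on this change is the one from compound 1 to compound 2, where the aryl group on the same saturated ring carbon was altered and the number rose modestly. A change of similar size is expected here, in the same direction, or none beyond the scatter, so the step from compound 3 to compound 4 is estimated as a 1.7-fold higher number from compound 3 to compound 4 (0.23 log units; within the scatter). Compound 4 is therefore expected to give about 6 nM in this assay, within a range of 2 nM to 15 nM.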

Compound 4, half-maximal inhibitory concentration: 26 nM
Estimate against measurement, compound 4: 4.3-fold (0.64 log units) below; the measured number lies above the stated range.
By their numbers in this assay, from the lowest: compound 1; then compounds 2 and 3 (each within the scatter of the next); then compound 4.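

The aryl group on this saturated ring carbon tolerates less than compounds 1 and 2 suggested: in this assay, the move to 4-aminophenyl gives a 7.4-fold higher number from compound 3 to compound 4 (0.87 log units; beyond the scatter), whereas the move to 3-hydroxyphenyl gave a 2.4-fold higher number from compound 1 to compound 2 (0.38 log units; beyond the scatter), on a different core. The leaving and entering groups match in heavy atom count, hydrogen-bond donors, hydrogen-bond acceptors and net charge, so those counts do not predict the response at this position. No measurement available here accounts for the larger step.

Oxygen gives way to nitrogen and the group's location on the phenyl ring shifts in the same change. 2-aminophenyl and 4-hydroxyphenyl would be needed to separate the two. Also open, as far as these compounds go, is whether 4-aminophenyl would produce a step of similar size on the core of compound 1.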